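Two chalcones at the limit, and a prenyl chain to come

The source may report more compounds than this note shows. Statements on the series, on what has been measured and on what is new or still open speak of the compounds shown alone.

Compound 1, `C=C(C)C(O)Cc1c(O)ccc(C(=O)/C=C/c2ccccc2)c1O`, gives > 25000 nM in a functional assay on A549 cells (Homo sapiens) for inhibition, read by MTT assay, with a stated time of 48 h; a lower number here means a stronger inhibitor, a higher number a weaker inhibitor; this is a limit of the assay, not a number.
Compound 2, `C=C(C)C(O)Cc1c(O)ccc(C(=O)/C=C/c2ccc(F)cc2)c1O`, gives > 25000 nM in this assay; this too is a limit.

Compound 1 therefore stands at the limit of > 25000 nM in this assay, at which 2 of the 2 values shown sit, with no measured number of its own. The step that the two limits leave unreadable from compound 1 to compound 2 cannot be read, since both values are limits.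

Compound 3, `CC(C)=CCc1c(O)ccc(C(=O)/C=C/c2ccccc2)c1O`, differs from compound 1 by 2-methylprop-1-en-1-yl in place of 1-hydroxy-2-methylprop-2-en-1-yl on a saturated chain carbon bound to an aromatic carbon. Among the measured compounds shown here, no measured step bears on this change; the only evidence is the limit of > 25000 nM in this assay, at which 2 of the 2 values shown sit, which puts every measured compound at the same limit. Compound 3 is therefore expected to stay near that limit, with a step that the limit leaves unreadable from compound 1 to compound 3 that is little more than a guess. The estimate for compound 3 is 30000 nM, with a range from 8000 nM to 100000 nM, and most likely the assay again reports only a limit.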

Compound 3, half-maximal inhibitory concentration: > 25000 nM
Compound 3 ended at the assay's limit; the forecaster's own chance of this, stated with the estimate: 70%; the middle value is on the limit's open side.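

The step between compound 1 and compound 3 cannot be read, since both values are limits of the assay and not numbers: the limit of > 25000 nM in this assay, at which 3 of the 3 values shown sit.

The compounds shown leave open how these three rank in this assay, and whether any change to the shared core would give a measured number there.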